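Compound 3 and its mirror-drawn stereocentre

The source may hold more compounds than are shown below. What is called first, only, known or untested is meant among the compounds shown, and "the series" means these compounds.

Compound 1 `CCn1c(C(=O)N[C@H](C)CO)ccc1C(CC)(CC)c1ccc(OCS(=O)(=O)c2ccccc2)c(C)c1`: 10600 nM
Compound 2 `CCn1c(C(=O)N[C@H](CO)CCO)ccc1C(CC)(CC)c1ccc(OCS(=O)(=O)c2ccccc2)c(C)c1`: 28500 nM
Compound 3 `CCn1c(C(=O)N[C@H](CO)CCCO)ccc1C(CC)(CC)c1ccc(OCS(=O)(=O)c2ccccc2)c(C)c1`: 31400 nM

In a functional assay on MCF7 cells (Homo sapiens) for antiproliferative activity, read by MTT assay, with a stated time of 24 h (on this read-out lower numbers stand for stronger inhibition and higher numbers for weaker inhibition), compound 3 gives 31400 nM. That value cannot be separated from its closest neighbour: a 1.1-fold higher number from compound 2 to compound 3 (0.04 log units; within the scatter). Against the smallest group on the amide-type nitrogen the gap is real but modest: a 3.0-fold higher number from compound 1 to compound 3 (0.47 log units; beyond the scatter).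

The next structure is compound 4 `CCn1c(C(=O)N[C@@H](CO)CCCO)ccc1C(CC)(CC)c1ccc(OCS(=O)(=O)c2ccccc2)c(C)c1`. The change is this: the two compounds have the same atoms and bonds and differ only in configuration as drawn: 1 of 1 stereo elements differ; a stereocentre at a saturated chain carbon is drawn S in compound 3 and R in compound 4. The stereocentre at a saturated chain carbon is drawn S in compound 3 and R in compound 4.

Within the data shown here, no measured step changes configuration, so none tests this directly. Among the measured compounds shown here, the only guide is how little the number has moved so far, with a 2.7-fold higher number from compound 1 to compound 2 (0.43 log units; beyond the scatter) as a modest step and the other two no larger. On that basis, no step beyond the scatter is expected in this assay, in either direction, though a pure change of configuration could still surprise. The expected step is a 1.1-fold lower number from compound 3 to compound 4 (0.05 log units; within the scatter). For compound 4 the estimated value is 28000 nM, within an expected range of 12000 nM to 60000 nM.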

Compound 4, half-maximal inhibitory concentration: 29600 nM
Beside the measured number, compound 4's estimate is 1.1-fold (0.02 log units) below it; measured number inside the range.
By their numbers in this assay, from the lowest: compound 1; then compounds 2, 4 and 3 (each within the scatter of the next).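

Among these compounds, the stereocentre at the saturated chain carbon, which no earlier step tested, can be drawn either way without a difference showing in this assay, with a 1.1-fold lower number from compound 3 to compound 4 (0.03 log units; within the scatter), and this comparison isolates configuration cleanly: the fact that compounds 3 and 4 differ only in the configuration as drawn. With the R drawing, the group of 7 heavy atoms also cannot be separated from 3-hydroxy-1-(hydroxymethyl)propyl, with a 1.0-fold higher number from compound 2 to compound 4 (0.02 log units; within the scatter). The gap to the smaller group survives the inversion, since 2-hydroxyethyl in place of hydrogen on that carbon gives a 2.8-fold higher number from compound 1 to compound 4 (0.45 log units; beyond the scatter), a real but modest step.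

The compounds shown leave open whether an amine or a carboxylic acid in place of the terminal hydroxy would move the number. They also leave open whether the two configurations would stay level with the 1-(hydroxymethyl)ethyl group of compound 1.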